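Changing the Anilino Ring on a Shared Core

A few compounds are considered here, and "the series" means these few. Any claim that something is new, unique, unknown or untested is made for them only; others in the source may bear on it.

Compound 2 `FC(F)(F)c1ccc(CSc2nc(Nc3ccccc3Cl)c3ccccc3n2)cc1` carries a (2-chlorophenyl)amino group on its core beside a benzyl thioether bearing a trifluoromethyl group. In a functional assay on MDA-MB-231 cells (Homo sapiens) for cytotoxicity, read by MTT assay, with a stated time of 72 h (a lower number here means a stronger inhibitor, a higher number a weaker inhibitor), compound 2 gives only a limit, > 50000 nM. Compound 3 `Cc1ccc(Nc2nc(SCc3ccc(C(F)(F)F)cc3)nc3ccccc23)cc1` carries a (4-methylphenyl)amino group in the same place, and in this assay compound 3 also gives only a limit, > 50000 nM. Compound 1 `FC(F)(F)c1ccc(CSc2nc(N3CCCCC3)c3ccccc3n2)cc1`, with piperidin-1-yl in that position, is the one of the three with a number: in this assay compound 1 gives 28400 nM. From compound 1 to compound 2 the step is an at least 1.7-fold higher number from compound 1 to compound 2 (0.24 log units; that floor lies within the scatter), and from compound 1 to compound 3 it is an at least 1.7-fold higher number from compound 1 to compound 3 (0.24 log units; that floor lies within the scatter), so both anilino compounds sit at the limit of > 50000 nM in this assay, at which 2 of the 3 values shown sit.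

Compound 4 `COc1ccc(Nc2nc(SCc3ccc(C(F)(F)F)cc3)nc3ccccc23)cc1OC` differs from compound 2 in one place: 3,4-dimethoxyphenyl in place of 2-chlorophenyl on a nitrogen on an aromatic ring. Going by the values given here, the only measured step between two anilino variants is a step that the two limits leave unreadable from compound 2 to compound 3, because both of its ends sit at the limit of > 50000 nM in this assay, at which 2 of the 3 values shown sit. Among the compounds with values here, no measured step therefore gives a readable size for this kind of change, and nothing points to a move beyond the scatter. The expected step is a number no higher from compound 2 to compound 4 (the limit leaves the size open), and compound 4 is expected to remain near the limit. Compound 4 is estimated at 50000 nM, with a range from 20000 nM to 120000 nM.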

Compound 4, half-maximal inhibitory concentration: 18900 nM
Compound 4: middle estimate off by 2.6-fold (0.42 log units), on the high side; the measured number lies below the stated range.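

The anilino ring is not a silent part of this position, as the two limits had left it looking: in this assay, placing 3,4-dimethoxyphenyl on the nitrogen gives an at least 2.6-fold lower number from compound 2 to compound 4 (0.42 log units; beyond the scatter), and the same group set against 4-methylphenyl gives an at least 2.6-fold lower number from compound 3 to compound 4 (0.42 log units; beyond the scatter). An anilino group at this position also need not cost activity, since replacing piperidin-1-yl with (3,4-dimethoxyphenyl)amino gives a 1.5-fold lower number from compound 1 to compound 4 (0.18 log units; within the scatter), which leaves compound 1 and compound 4 indistinguishable in this assay, even though compound 2 and compound 3 go against any rule that anilino groups match piperidin-1-yl. Both steps from the limits are floors, and their true sizes stay unknown because compound 2 and compound 3 each give only a limit: the limit of > 50000 nM in this assay, at which 2 of the 4 values shown sit.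

The compounds shown leave open whether both methoxy groups are needed, as a ring with a single methoxy group would be the direct test of that. They also leave open how far the trend runs on the anilino ring, for example with a carboxylic acid there, and whether a morpholine in place of piperidin-1-yl would read differently in this assay.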